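Aryl substituent change in the urea series

The source may hold more compounds than are shown below. What is called first, only, known or untested is meant among the compounds shown, and "the series" means these compounds.

Among the measured compounds shown here, compound 2 `COc1ccc(CC2c3ccc(OC)cc3CCC2NC(=O)Nc2cccc3cnccc23)cc1` is the only member of the series with a number in a functional assay on HEK293 cells for antagonist activity at transient receptor potential cation channel subfamily V member 1 (Homo sapiens), read by FLIPR; a lower number here means a stronger inhibitor, a higher number a weaker inhibitor; compound 2 gives 36 nM there. Compound 1 `COc1ccc2c(c1)CCC(NC(=O)Nc1cccc3cnccc13)C2Cc1cccnc1` is reported in this assay only as a limit, > 1000 nM (the limit of > 1000 nM in this assay, at which 1 of the 2 values shown sits). For the measured compounds named here, the single measured step, an at least 27-fold lower number from compound 1 to compound 2 (1.44 log units; beyond the scatter), shows that the group on the saturated chain carbon bound to a saturated ring carbon moves the number strongly. Compound 3 `COc1ccc2c(c1)CCC(NC(=O)Nc1cccc3cnccc13)C2Cc1ccc(C(F)(F)F)cc1` differs from compound 2 by trifluoromethyl in place of methoxy on an aromatic carbon. The change stays on the same aryl group, so the measured step bears on it only by showing that this part of the molecule is sensitive; it gives no reading of methoxy against trifluoromethyl. A step in this assay of modest size, possibly in either direction, is therefore expected. Compound 3 is estimated at 60 nM, with a range from 15 nM to 300 nM. That estimate corresponds to an expected 1.7-fold higher number from compound 2 to compound 3 (0.22 log units; within the scatter).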

Compound 3, half-maximal inhibitory concentration: 2 nM
The estimate for compound 3 lay 30-fold (1.48 log units) above the measured number, outside the stated range (below it).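

Within the benzyl group, the substituent matters and not only the aryl ring: trifluoromethyl in place of methoxy gives an 18-fold lower number from compound 2 to compound 3 (1.26 log units; beyond the scatter) in this assay and not a modest shift. Compound 3 therefore holds the lowest number of the three, with its steps to both other compounds printed as beyond the scatter. Replacing the pyridin-3-yl group with 4-(trifluoromethyl)phenyl gives an at least 500-fold lower number from compound 1 to compound 3 (2.69 log units; beyond the scatter) and this span is only a bound, since compound 1 is reported as a limit: the limit of > 1000 nM in this assay, at which 1 of the 3 values shown sits.

With only methoxy and trifluoromethyl on this aromatic carbon, the compounds shown do not tell whether a chlorine, a nitrile or a tert-butyl group there would read closer to compound 2 or to compound 3. They also leave open how a longer chain in place of the benzyl link would read.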